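A few compounds are considered here, and "the series" means these few. Any claim that something is new, unique, unknown or untested is made for them only; others in the source may bear on it.

Measured so far:
- compound 1 `Cn1c(NN)nc(-c2cccc(O)c2O)c(C#N)c1=O`: 34 ug/mL
- compound 2 `CCOC(=O)c1cnn(-c2nc(-c3ccccc3Cl)c(C#N)c(=O)n2C)c1N`: 78 ug/mL
- compound 3 `CCOC(=O)c1cnn(-c2nc(-c3cccs3)c(C#N)c(=O)n2C)c1N`: 79 ug/mL

In a functional assay, with a stated time of 20 min (on this read-out lower numbers stand for stronger inhibition and higher numbers for weaker inhibition), compound 1 gives the lowest number of the three, with compound 2 and compound 3 both beyond the scatter above it. Compound 4 `CSc1nc(-c2cccc(O)c2O)c(C#N)c(=O)n1C` differs from compound 1 in one place: methylsulfanyl in place of aminoamino on an aromatic carbon. Within the data shown here, the only measured step, a 1.0-fold higher number from compound 2 to compound 3 (0.01 log units; within the scatter), concerns a different place and falls within the scatter, so it gives no guide for the change at this carbon between two ring nitrogen atoms. With no comparable step shown, the expectation for compound 4 is a small step toward weaker inhibition or none beyond the scatter, a 1.5-fold higher number from compound 1 to compound 4 (0.17 log units; within the scatter). Compound 4 is therefore estimated at 50 ug/mL, ranging from 20 ug/mL to 130 ug/mL.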

Compound 4, half-maximal inhibitory concentration: 48 ug/mL
For compound 4 the middle estimate is 1.0-fold (0.02 log units) above the measured one; the measured number falls inside the stated range.
By their numbers in this assay, from the lowest: compounds 1, 4, 2 and 3 (each within the scatter of the next, the first and the last beyond it).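

On the aromatic carbon between two ring nitrogen atoms, methylsulfanyl in place of aminoamino in this assay gives a 1.4-fold higher number from compound 1 to compound 4 (0.15 log units; within the scatter) and so stays within the scatter. In this one pair, the hydrogen-bond donors of aminoamino are lost without a step beyond the scatter. No measurement shown offers an explanation for this result. Still open, on these data alone, is how a simple amine, a methoxy group or a longer alkylsulfanyl chain would read at this carbon. Also open, as far as these compounds go, is whether this swap gives a similar step on compounds carrying other aryl groups.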